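A Dihydroxyphenyl Swap on Compound 2

The source may report more compounds than this note shows. Statements on the series, on what has been measured and on what is new or still open speak of the compounds shown alone.

Three related compounds have been tested so far in a functional assay on HeLa cells (Homo sapiens) for inhibition, read by CCK-8 assay, with a stated time of 48 h; on this read-out higher numbers stand for weaker inhibition and lower numbers for stronger inhibition. Compound 1 (`COc1ccc(NC(=O)NCCNS(=O)(=O)c2ccc(-c3ccccc3OCc3ccccc3)s2)cc1`) gives > 50000 nM, which is a limit of the assay and not a number. Compound 3 (`CC(C)c1ccc(Oc2ccc(O)c(O)c2)c(-c2ccsc2S(=O)(=O)NCCNC(=O)Nc2cc(Cl)cc(Cl)c2)c1`) gives > 50000 nM, which is also a limit. Among the measured compounds shown here, compound 2 (`O=S(=O)(NCCNC(=S)Nc1cc(C(F)(F)F)cc(C(F)(F)F)c1)c1ccc(-c2ccccc2O[C@H]2CC[C@@H](O)CC2)s1`) gives 10900 nM, the only true number among the three, so it is the single firm reference point in this assay.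

Compound 4 (`O=S(=O)(NCCNC(=S)Nc1cc(C(F)(F)F)cc(C(F)(F)F)c1)c1ccc(-c2ccccc2Oc2ccc(O)c(O)c2)s1`) is still unmeasured and differs from compound 2 in one place: 3,4-dihydroxyphenyl in place of 4-hydroxycyclohexyl on an oxygen on an aromatic ring. In words, this puts 3,4-dihydroxyphenyl in place of 4-hydroxycyclohexyl on an oxygen on an aromatic ring. For the measured compounds named here, no measured pair shows what this exchange does, so the expectation starts from compound 2 at 10900 nM. The estimated change, a 1.4-fold lower number from compound 2 to compound 4 (0.13 log units; within the scatter), is expected to be small, with only a slight lean towards stronger inhibition. Compound 4 is expected at about 8000 nM, with an estimated range of 2000 nM to 35000 nM.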

Compound 4, half-maximal inhibitory concentration: > 20000 nM
Compound 4: no number, only a limit (the forecaster's own chance of this, stated with the estimate: 20%); at least 2.5-fold (0.39 log units) between middle value and limit.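

Placing 3,4-dihydroxyphenyl on this oxygen in place of 4-hydroxycyclohexyl gives an at least 1.8-fold higher number from compound 2 to compound 4 (0.26 log units; that floor lies within the scatter) in this assay, the first reading of any change at this position. Compound 4 gives a limit of the assay and not a number: the limit of > 20000 nM in this assay, at which 1 of the 4 values shown sits. The aromatic ring with its two hydroxyl groups therefore brings no stronger inhibition than the 4-hydroxycyclohexyl group of compound 2, and the true gap may be wider than the printed floor.

The exchange swaps the ring and adds a hydroxyl group in one move, so the compounds shown cannot separate what each of those two changes does. Also open, as far as these compounds go, is how this position would respond to a simple phenyl group with no hydroxyl, or to an amine or a carboxylic acid in place of the hydroxyl of 4-hydroxycyclohexyl.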